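Lengthening the chain once more: compound 3 to compound 4

The compounds below may be only part of what the source reports. "The series", "measured", "known", "first", "only" and "open" are said of these compounds alone.

Compound 1 `CC(CCO)n1cnc2c(Cl)ncnc21`: > 50000 nM, a limit
Compound 2 `CCCCCC(CCO)n1cnc2c(Cl)ncnc21`: > 50000 nM, a limit
Compound 3 `CCCCCCC(CCO)n1cnc2c(Cl)ncnc21`: 16700 nM

Going by the values given here, in a functional assay on SW480 cells (Homo sapiens) for antiproliferative activity, read by MTT assay, with a stated time of 48 h (on this read-out lower numbers stand for stronger inhibition and higher numbers for weaker inhibition), compound 3 gives 16700 nM, the only true number among the three. Compounds 1 and 2 stand at the limit of > 50000 nM in this assay, at which 2 of the 3 values shown sit.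

The next compound is compound 4 `CCCCCCCC(CCO)n1cnc2c(Cl)ncnc21`, and the change is methyl in place of hydrogen on a saturated chain carbon, seven bonds along the chain from an aromatic nitrogen. The closest measured step is an at least 2.9-fold lower number from compound 2 to compound 3 (0.47 log units; beyond the scatter), likewise methyl in place of hydrogen on the chain. The longer step of an at least 2.9-fold lower number from compound 1 to compound 3 (0.47 log units; beyond the scatter) points the same way. Both start from a limit. A further modest step to a lower number is therefore expected, and the estimated step is a 2.1-fold lower number from compound 3 to compound 4 (0.32 log units; beyond the scatter). For compound 4 the expected value is 8000 nM, with an estimated range of 3000 nM to 22000 nM.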

Compound 4, half-maximal inhibitory concentration: 3630 nM
Beside the measured number, compound 4's estimate is 2.2-fold (0.34 log units) above it, and the stated range covers the measured number.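

In this assay, going by these compounds alone, the chain now gives a step between two true numbers, so its size can be read for the first time: a 4.6-fold lower number from compound 3 to compound 4 (0.66 log units; beyond the scatter). Measured against the weakest end of the series, the gain grows to an at least 13-fold lower number from compound 2 to compound 4 (1.13 log units; beyond the scatter) and an at least 13-fold lower number from compound 1 to compound 4 (1.13 log units; beyond the scatter), which shows that the lowering seen at compound 3 continues at compound 4. These two longer steps start from a limit: the limit of > 50000 nM in this assay, at which 2 of the 4 values shown sit.

The compounds shown leave open whether a longer chain would lower the number further or whether the trend ends. They also do not show how an amine or a carboxylic acid at the chain end would compare with the hydroxyl.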